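Cytotoxicity notes on compounds 1 to 4

The compounds below may be only part of what the source reports. "The series", "measured", "known", "first", "only" and "open" are said of these compounds alone.

compound 1 `COc1cc2nc(Nc3ccc(C#N)cc3)nc(Nc3c(C)cc(/C=C/C#N)cc3F)c2cc1OC` — > 52000 nM
compound 2 `COc1cc2nc(SCC(=O)Nc3ccc(C(F)(F)F)cc3)nc(Nc3c(Cl)cc(/C=C/C#N)cc3Cl)c2cc1OC` — > 197000 nM
compound 3 `COc1cc2nc([S+]([O-])CC(=O)Nc3ccccc3C(F)(F)F)nc(Nc3c(Cl)cc(/C=C/C#N)cc3Cl)c2cc1OC` — > 192000 nM

The read-out of an ADME assay on MT4 cells (Homo sapiens) for cytotoxicity, read by MTT assay, with a stated time of 5 days (a lower number here means that less compound is tolerated, a higher number that more compound is tolerated), is the half-maximal cytotoxic concentration. For compound 1 the entry > 52000 nM is a limit of the assay, not a number. For compound 2 the entry > 197000 nM is likewise a limit. For compound 3 the entry > 192000 nM is a limit as well. For the measured compounds named here, compound 3 therefore stands where every compound tested so far stands: at the ceiling of what this assay reports, with no numerical value and no measurable separation from compound 1 or compound 2. Going by the values given here, no step between measured compounds can be sized here.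

Compound 4 `COc1cccc(NC(=O)C[S+]([O-])c2nc(Nc3c(Cl)cc(/C=C/C#N)cc3Cl)c3cc(OC)c(OC)cc3n2)c1` is the compound still to be tested. It differs from compound 3 by 3-methoxyphenyl in place of 2-(trifluoromethyl)phenyl on an amide-type nitrogen.

Given that all three shown values are limits (the limit of > 192000 nM in this assay, at which 1 of the 3 values shown sits, (the limit of > 197000 nM in this assay, at which 1 of the 3 values shown sits), (the limit of > 52000 nM in this assay, at which 1 of the 3 values shown sits)), the expectation for compound 4 in this assay is a further limit rather than a number, with no step beyond the scatter. The step that the limit leaves unreadable from compound 3 to compound 4 is accordingly expected to be negligible. Compound 4 is estimated at 200000 nM, within a range from 80000 nM to 400000 nM.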

Compound 4, half-maximal cytotoxic concentration: >= 167000 nM
Compound 4 was reported as a limit; the forecaster's own chance of this, stated with the estimate: 85%; the middle value lies beyond the limit too.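

In this assay compound 4 gives >= 167000 nM, which is a limit of the assay and not a number. For the compounds shown here, compound 3 is likewise recorded only as a limit, so no step between compound 3 and compound 4 can be read. The compounds shown leave open whether 3-methoxyphenyl and 2-(trifluoromethyl)phenyl differ at all in half-maximal cytotoxic concentration.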